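The compounds below may be only part of what the source reports. "The series", "measured", "known", "first", "only" and "open" are said of these compounds alone.

In an ADME assay on Vero cells (Chlorocebus sabaeus) for cytotoxicity, read by sulforhodamine B assay, with a stated time of 72 h (a lower number here means a stronger inhibitor, a higher number a weaker inhibitor), compound 2 `CN1Cc2ccc(OCc3ccc(-c4ccccc4)cc3)cc2[C@@H](O)C1` gives 23000 nM, the lowest of the two plain numbers shown. The nearest is compound 3 `CN1Cc2ccc(OCc3ccc(-c4ccc(F)cc4)cc3)cc2[C@@H](O)C1`, which gives 33800 nM, a step of a 1.5-fold higher number from compound 2 to compound 3 (0.17 log units; within the scatter) that lies within the scatter, so no order can be drawn between the two. Compound 1 `CN1Cc2ccc(OCc3ccccc3)cc2[C@@H](O)C1` reaches only a limit of this assay, > 100000 nM, which is the limit of > 100000 nM in this assay, at which 1 of the 3 values shown sits. The measured steps of an at least 4.3-fold lower number from compound 1 to compound 2 (0.63 log units; beyond the scatter) and an at least 2.9-fold lower number from compound 1 to compound 3 (0.47 log units; beyond the scatter) each add a group on an aromatic carbon and are at least modest. Compound 4 `CN1CCc2cc(OCc3ccc(-c4ccccc4)cc3)ccc2C1` differs from compound 2 by hydrogen in place of hydroxy on a saturated ring carbon. For the measured compounds named here, none of the measured steps touches that saturated ring carbon; all of them concern an aromatic carbon, so no measured step bears directly on this change, and the expectation rests on the remainder of the structure being unchanged. A step of a 1.3-fold lower number from compound 2 to compound 4 (0.11 log units; within the scatter) is therefore expected, that is none beyond the scatter. The estimate for compound 4 in this assay is 18000 nM, with a range from 6000 nM to 60000 nM.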

Compound 4, half-maximal inhibitory concentration: 16500 nM
Compound 4: the middle estimate sits 1.1-fold (0.04 log units) above what was measured; the range from low to high includes it.
By their numbers in this assay, from the lowest: compounds 4, 2 and 3 (each within the scatter of the next, the first and the last beyond it). At a limit, above all of these: compound 1.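

The earlier steps shown here all concerned an aromatic carbon, whereas this one falls on a saturated ring carbon, two ring bonds from the ring nitrogen. In this assay, hydrogen in place of hydroxy at that carbon gives a 1.4-fold lower number from compound 2 to compound 4 (0.14 log units; within the scatter), so the exchange leaves the reading within the scatter and the hydroxy is not required for a plain number in this series. Compound 1 alone remains at a limit, which is not a number: the limit of > 100000 nM in this assay, at which 1 of the 4 values shown sits.

Other groups on that saturated ring carbon, such as a methoxy, an amine or a carbonyl, are not among the compounds shown, so how this carbon responds to anything beyond hydroxy and hydrogen stays open. Whether the same exchange would behave alike in compound 1 or compound 3 also stays open, as the compounds shown hold it only against compound 2.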